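A Chloro Exchange on the Least Bound Compound

This account rests on a few compounds, and the source may have more. Where it says the series, first, only, none or still open, it means among the compounds named here.

In an ADME assay on a cell-free system (plasma, Homo sapiens) for protein binding, compound 1 (`COCCOc1cc2oc(=O)n(CCC(=O)O)c2cc1Cl`) gives 70.7%, the highest unbound fraction of the three measured compounds. Compound 3 (`Cc1ccc([C@@H](C)Oc2cc3oc(=O)n(CCC(=O)O)c3cc2Cl)nc1`) gives 97.8% and compound 2 (`Cc1ccc([C@@H](C)Oc2cc3onc(CCC(=O)O)c3cc2Cl)nc1`) gives 99.7%, both with unbound fractions well beyond the scatter from compound 1. Compound 4 (`O=C(O)CCn1c(=O)oc2cc(Cl)c(Cl)cc21`) has chloro in place of 2-methoxyethoxy on an aromatic carbon. Among the compounds with values here, no measured pair isolates this exchange, so the expectation is only a judgment. In this assay, a shift towards stronger binding beyond the scatter is expected, with an estimated a 3.7-fold lower unbound fraction from compound 1 to compound 4 (0.56 log units; beyond the scatter). For compound 4, the estimated value is 92%, with an expected range of 82% to 97.5%.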

Compound 4, plasma protein binding: 98.2%
Compound 4: the middle estimate sits 4.4-fold (0.65 log units) (unbound fraction) above what was measured; the whole stated range lies below it.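

In this assay, this aromatic carbon, ortho to a chloro group, proves highly sensitive: chloro in place of 2-methoxyethoxy gives a 16-fold lower unbound fraction from compound 1 to compound 4 (1.21 log units; beyond the scatter). This single exchange, with one heavy atom entering and no ring, is enough to bring binding into the range of the far larger substituent of compound 3. Nothing measured here accounts for the size of this step. Going by these compounds, whether an amine or a longer ether chain at this position would leave more of the compound unbound remains open, as does whether the same exchange would act alike on the core of compound 2.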